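The compounds below may be only part of what the source reports. "The series", "measured", "known", "first", "only" and "open" are said of these compounds alone.

Measured so far in a functional assay on THP-1 cells (Homo sapiens) for inhibition, read by sulforhodamine B assay, with a stated time of 48 h, tested at 50 uM; on this read-out lower numbers stand for less inhibition of growth and higher numbers for more inhibition of growth at the one concentration tested:

- compound 1 `COc1cc(/C=C/C(=O)/C=C/c2cccc3ccccc23)ccc1OCc1cn(CCOc2cc(=O)oc3ccccc23)nn1`: 89%
- compound 2 `COc1cc(/C=C/C(=O)/C=C/c2cc(OC)c(OC)c(OC)c2)ccc1OCc1cn(CCOc2cc(=O)oc3ccccc23)nn1`: 99%

Compound 2 gives 99%, and compound 1 gives 89%. These two values lie within the scatter of each other, so this pair cannot be ranked, and both compounds show strong growth inhibition at the one concentration tested.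

The next compound is compound 3 `COc1ccc(/C=C/C(=O)/C=C/c2ccc(OCc3cn(CCOc4cc(=O)oc5ccccc45)nn3)c(OC)c2)cc1OC`, which differs from compound 2 in one place: hydrogen in place of methoxy on an aromatic carbon. Put simply, hydrogen stands in place of methoxy on an aromatic carbon, so 3,4,5-trimethoxyphenyl becomes 3,4-dimethoxyphenyl.

Within the data shown here, only one measured step bears on this change, and it concerns the same group: a number 10 percentage points higher from compound 1 to compound 2 (within the scatter). That step exchanged naphthalen-1-yl for 3,4,5-trimethoxyphenyl, a larger replacement than the loss of one methoxy, and it did not leave the scatter. No step beyond the scatter is therefore expected in this assay, although one step is thin evidence.

The expected change is a number 6 percentage points lower from compound 2 to compound 3 (within the scatter).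

For compound 3 the estimated value is 93%, with an expected range from 78% to 100%.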

Compound 3, percent growth inhibition at one concentration: 90%
Compound 3: middle estimate off by 3 percentage points, on the high side; the measured number falls inside the stated range.
By their numbers in this assay, from the lowest: compounds 1, 3 and 2 (each within the scatter of the next).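

Taking one methoxy off the 3,4,5-trimethoxyphenyl group to leave 3,4-dimethoxyphenyl gives a number 9 percentage points lower from compound 2 to compound 3 (within the scatter) in this assay, so this aromatic carbon carries hydrogen or methoxy with no difference that this read-out can resolve. The earlier step exchanged a whole aryl group, whereas this one changes a single substituent, and a number 1 percentage points higher from compound 1 to compound 3 (within the scatter) adds that 3,4-dimethoxyphenyl and naphthalen-1-yl cannot be ranked either, leaving all three compounds with strong growth inhibition at the one concentration tested. No measurement offered here accounts for these results.

As far as these compounds go, what stays open is whether a different kind of group on this aromatic carbon, such as an amine or a carboxylic acid, would move the number beyond the scatter, and whether a plain phenyl ring without any methoxy would do so. From the compounds shown here alone, since all three values lie near the top of the scale at a single concentration, it also remains open whether these compounds would separate at lower concentrations.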